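Compound 4: trifluoromethyl in place of bromo

This account rests on a few compounds, and the source may have more. Where it says the series, first, only, none or still open, it means among the compounds named here.

Compound 1, `C=C1C[C@]23C[C@@]1(O)CC[C@@H]2c1cccc(C)c1[C@@H]3Cn1cc(-c2ccc(Br)cc2)nn1`, gives in a functional assay on A549 cells (Homo sapiens) for cytotoxicity, read by MTT assay, with a stated time of 4 days (a lower number here means a stronger inhibitor, a higher number a weaker inhibitor), only a limit, > 20000 nM; it sits at the limit (the limit of > 20000 nM in this assay, at which 1 of the 3 values shown sits). Two related compounds carry a different core, with a carbonyl and a hydroxy group: compound 2, `C=C1C(=O)[C@]23C[C@@]1(O)CC[C@H]2c1ccc(O)c(C)c1[C@@H]3Cn1cc(-c2ccc(C)cc2)nn1`, gives 1260 nM in this assay, and compound 3, `C=C1C(=O)[C@]23C[C@@]1(O)CC[C@H]2c1ccc(O)c(C)c1[C@@H]3Cn1cc(-c2ccccn2)nn1`, gives 1570 nM. Within the data shown here, the single measured step between them, a 1.2-fold higher number from compound 2 to compound 3 (0.10 log units; within the scatter), exchanges the aromatic group on the same side of the molecule as the change now considered and stays within the scatter.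

Compound 4, `C=C1C[C@]23C[C@@]1(O)CC[C@@H]2c1cccc(C)c1[C@@H]3Cn1cc(-c2ccc(C(F)(F)F)cc2)nn1`, differs from compound 1 by trifluoromethyl in place of bromo on an aromatic carbon. Among the measured compounds shown here, no measured step exchanges bromo for trifluoromethyl, and the step from compound 2 to compound 3 sits on a core that compound 1 and compound 4 do not share, so it bears on the question only loosely, as a sign that exchanging the aromatic group here moves the numbers little. Compound 1 stands only at a limit. For compound 4 the expected step that the limit leaves unreadable from compound 1 to compound 4 is one within the scatter. Compound 4 is thus estimated at 30000 nM, in a range from 8000 nM to 100000 nM, and is expected most likely to be reported as a limit again.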

Compound 4, half-maximal inhibitory concentration: > 20000 nM
Compound 4 ended at the assay's limit (the forecaster's own chance of this, stated with the estimate: 75%); the middle value lies beyond the limit too.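

Compound 1 and compound 4 both stand only at a limit in this assay, so no step can be read for trifluoromethyl in place of bromo: the limit of > 20000 nM in this assay, at which 2 of the 4 values shown sit.

The compounds shown leave open whether 4-bromophenyl to 4-(trifluoromethyl)phenyl changes the read-out at all on the core of compound 1, and whether any aromatic group on that core gives a value short of the limit.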